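Methoxy to hydroxy in the nitrooxy ester series

The source may hold more compounds than are shown below. What is called first, only, known or untested is meant among the compounds shown, and "the series" means these compounds.

Values so far in a functional assay on A549 cells (Homo sapiens) for cytotoxicity, read by resazurin assay, with a stated time of 72 h (a higher number here means a weaker inhibitor, a lower number a stronger inhibitor), are as follows:
compound 1 `COc1cc(/C=C/C(=O)OCCCO[N+](=O)[O-])ccc1OCCCO[N+](=O)[O-]` gives 15800 nM
compound 2 `COc1cc(/C=C/C(=O)OCCCO[N+](=O)[O-])ccc1O` gives 13200 nM
compound 3 `COc1cc(/C=C/C(=O)OCCCCCO[N+](=O)[O-])ccc1OCCCCCO[N+](=O)[O-]` gives > 50000 nM (a limit of the assay, not a number)

Compound 1 has a single numeric neighbour in this assay and the measured step to it is a 1.2-fold lower number from compound 1 to compound 2 (0.08 log units; within the scatter) so the two stand together. Compound 3 offers only a limit.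

The step of interest leads to the unmeasured compound 4 `O=C(/C=C/c1ccc(OCCCO[N+](=O)[O-])c(O)c1)OCCCO[N+](=O)[O-]` and reads methoxy to hydroxy hydrogen in place of methyl on an oxygen on an aromatic ring with hydrogen in place of methyl on an oxygen on an aromatic ring. Going by the values given here, no measured step has this exact replacement. The closest guide is the replacement on an oxygen on an aromatic ring that gives compound 2, where hydrogen takes the place of 3-(nitrooxy)propyl. That step is a 1.2-fold lower number from compound 1 to compound 2 (0.08 log units; within the scatter) and it removes a larger group than methyl without leaving the scatter. No move beyond the scatter is therefore expected in this assay and no firm direction can be assigned. The expected step is a 1.3-fold lower number from compound 1 to compound 4 (0.12 log units; within the scatter) and it remains an estimate resting on one indirect comparison. For compound 4 the estimated value is 12000 nM with an expected range from 5000 nM to 30000 nM as the working bracket.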

Compound 4, half-maximal inhibitory concentration: 690 nM
Compound 4: the middle estimate sits 17-fold (1.24 log units) above what was measured, and the stated range ends above it.
By their numbers in this assay, from the lowest: compound 4; then compounds 2 and 1 (each within the scatter of the next). At a limit, above all of these: compound 3.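

In this assay, hydrogen in place of methyl on an oxygen on an aromatic ring gives a 23-fold lower number from compound 1 to compound 4 (1.36 log units; beyond the scatter), so this small change, which removes a single carbon, is enough to move the number well beyond the scatter. The earlier step at the oxygen carrying 3-(nitrooxy)propyl, a 1.2-fold lower number from compound 1 to compound 2 (0.08 log units; within the scatter), stays within the scatter, so the two oxygens on the aromatic ring of the core do not respond alike, and the methoxy-to-hydroxy site is the one of the two where a large step has been seen in this series. Nothing measured here explains the size of this step, and the values shown give no account of why it occurs.

Whether the gain comes from the free hydroxy itself or only from the loss of methyl stays open, since no other group, such as an ethyl ether or an amine, stands at that place among the compounds shown. As far as these compounds go, compound 3 gives > 50000 nM, a limit of the assay, and whether hydroxy in place of methoxy would act the same way on its longer chains stays open.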